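A few compounds are considered here, and "the series" means these few. Any claim that something is new, unique, unknown or untested is made for them only; others in the source may bear on it.

Measured so far:
compound 1 `CCOC(=O)N1CCC(NC(=O)Nc2ccc(C(F)(F)F)c(F)c2)CC1`, 5.46
compound 2 `CCOC(=O)N1CCC(NC(=O)Nc2ccc(OC(F)(F)F)c(F)c2)CC1`, 5.94
compound 3 `CC[C@H](C)C(=O)N1CCC(NC(=O)Nc2ccc(OC(F)(F)F)c(Cl)c2)CC1`, 7.7

All three numbers come from a physicochemical assay for lipophilicity, read by HPLC, with a stated time of 90 min, tested at 100 uM; a lower number here means a more polar compound, a higher number a more lipophilic compound. Compound 2 stands second highest of the three: the step of a number 0.48 log units higher from compound 1 to compound 2 (beyond the scatter) places it above compound 1, while compound 3, which differs from compound 2 in two places at once, gives the highest number of all. Compound 4 `O=C(Nc1ccc(OC(F)(F)F)c(F)c1)NC1CCN(C(=O)[C@@H]2CCOC2)CC1` is the next compound. Its change from compound 2 is oxolan-3-yl in place of ethoxy on a carbonyl carbon. Among the measured compounds shown here, no measured step touches that carbonyl carbon; the only measured step, a number 0.48 log units higher from compound 1 to compound 2 (beyond the scatter), concerns a different part of the molecule, and the gap between compound 2 and compound 3 mixes two changes. With nothing closer to lean on, a step within the scatter is expected, a number 0.14 log units lower from compound 2 to compound 4 (within the scatter). Compound 4 is therefore estimated at 5.8, between 5.1 and 6.5.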

Compound 4, partition coefficient: 3.59
Estimate against measurement, compound 4: 2.21 log units above; the whole stated range lies above it.
By their numbers in this assay, from the lowest: compound 4; then compound 1; then compound 2; then compound 3.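

This carbonyl carbon turns out to be a highly sensitive place in this assay: the step of a number 2.35 log units lower from compound 2 to compound 4 (beyond the scatter) is far larger than the earlier one, a number 0.48 log units higher from compound 1 to compound 2 (beyond the scatter), made elsewhere on the molecule. The number falls even though oxolan-3-yl brings more heavy atoms than ethoxy, adds a ring, and keeps the same count of hydrogen-bond acceptors. No measurement at hand explains this drop. Still open, on these data alone, is how the ring oxygen counts towards the step, which a cyclopentyl group at this carbon would test; an amine-bearing chain there is equally uncharted.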